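The compounds below may be only part of what the source reports. "The series", "measured", "known", "first", "only" and "open" are said of these compounds alone.

Compound 1 `C=CC1=C(C(=O)Nc2ccccc2)C(c2ccc(OC)cc2)OC1` is the starting point. In a functional assay on SW480 cells (Homo sapiens) for cytotoxicity, read by MTT assay, with a stated time of 24 h (on this read-out lower numbers stand for stronger inhibition and higher numbers for weaker inhibition), compound 1 gives only a limit, > 100000 nM, so where it stands among the numbers shown rests on the limit of > 100000 nM in this assay, at which 1 of the 2 values shown sits, rather than on a measured value. Compound 2 `C=CC1=C(C(=O)Nc2ccccc2)C(c2ccc(OC)c(OC)c2)OC1` differs from it by methoxy in place of hydrogen on an aromatic carbon; in this assay compound 2 gives 45100 nM, and the step of an at least 2.2-fold lower number from compound 1 to compound 2 (0.34 log units; beyond the scatter) is the only measured one. Compound 3 `C=CC1=C(C(=O)Nc2ccc(C)cc2)C(c2ccc(OC)cc2)OC1` carries a different change: methyl in place of hydrogen on an aromatic carbon. For the measured compounds named here, no measured step concerns a methyl group; the methoxy step is the sole comparison and it does not bear directly on this change. The group that enters is small and brings no hydrogen-bond donor or acceptor, and a step beyond the scatter is not expected. The step that the limit leaves unreadable from compound 1 to compound 3 is therefore estimated to be minor. Compound 3 is estimated at 110000 nM, between 40000 nM and 300000 nM, with a real chance that only a limit is again recorded.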

Compound 3, half-maximal inhibitory concentration: > 100000 nM
Compound 3 was reported as a limit (the forecaster's own chance of this, stated with the estimate: 55%); the middle value lies beyond the limit too.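

Compound 3, like compound 1, is recorded only as a limit in this assay, so no step between them can be read: the limit of > 100000 nM in this assay, at which 2 of the 3 values shown sit.

The compounds shown leave open whether methyl in place of hydrogen on an aromatic carbon changes the number at all.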